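Swapping the aryl ketone of a chalcone-pyrazole for difluorophenyl

The source may hold more compounds than are shown below. What is called first, only, known or untested is meant among the compounds shown, and "the series" means these compounds.

Measured compounds:
- compound 1, `COc1ccc(-c2cc(/C=C/C(=O)c3ccc(N)cc3)[nH]n2)cc1`: 97%
- compound 2, `COc1ccc(C(=O)/C=C/c2cc(-c3cc(OC)c(OC)c(OC)c3)n[nH]2)cc1OC`: 99%

Two compounds share a chalcone-like chain joined to a pyrazole. In a functional assay on CAKI-1 cells (Homo sapiens) for cytotoxicity, read by sulforhodamine B assay, with a stated time of 48 h, tested at 0.1 uM (a higher number here means a weaker effect of the compound at the concentration tested, a lower number a stronger effect), compound 1 gives 97%. In this assay compound 2 gives 99%. Compound 2 holds the higher of the two numbers, but its value and that of compound 1 lie within the usual scatter of each other, so the two cannot be told apart; both readings sit close to full activity, which means neither compound reduces the cells' growth noticeably at the concentration tested.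

Compound 3, `COc1cc(-c2cc(/C=C/C(=O)c3ccc(F)c(F)c3)[nH]n2)cc(OC)c1OC`, has not been measured. It differs from compound 2 in one place: 3,4-difluorophenyl in place of 3,4-dimethoxyphenyl on a carbonyl carbon. The rest of the molecule, the pyrazole carrying the trimethoxyphenyl group and the unsaturated linker, is unchanged.

Among the measured compounds shown here, with no measured step of this kind to lean on, the expectation rests on the two values at hand, which show no effect beyond the scatter. The step of a number 3 percentage points lower from compound 2 to compound 3 (within the scatter) is therefore expected to be small, with no direction beyond the scatter. For compound 3 in this assay the estimate is 96%, expected to fall between 85% and 104%.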

Compound 3, a percentage reported as activity, at one concentration (the size of the read-out at that concentration, not a potency): 94%
The estimate for compound 3 lay 2 percentage points above the measured number; measured number inside the range.
By their numbers in this assay, from the lowest: compounds 3, 1 and 2 (each within the scatter of the next).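

At this position, on a carbonyl carbon, putting 3,4-difluorophenyl in place of 3,4-dimethoxyphenyl gives a number 5 percentage points lower from compound 2 to compound 3 (within the scatter) in this assay. Among the compounds shown here, this is the first direct test of the position, and it shows that the read-out at this single concentration does not tell compound 2 and compound 3 apart, even though the two groups differ in their atoms and in their count of hydrogen-bond acceptors. The change therefore does not bring out a measurable effect on the cells here, and no measurement at hand offers an explanation for this result.

The compounds shown leave open whether a quite different group on this carbonyl carbon, such as a phenyl ring carrying a carboxylic acid or a nitrile, would move the number beyond the scatter. They also leave open whether compound 2 and compound 3 would separate at a higher concentration, since a reading at one concentration near full activity says little about how the two would compare once an effect appears.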